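Five-membered heteroaryl replacing pyridyl at compound 4

This account rests on a few compounds, and the source may have more. Where it says the series, first, only, none or still open, it means among the compounds named here.

Compound 3 `c1cncc(-c2cccc3c2CCC3c2ncc[nH]2)c1` returns only > 10000 nM in a functional assay on CHO cells for agonist activity at Alpha-1D adrenergic receptor (Homo sapiens), read by FLIPR and calcium flux; a lower number here means that less compound is needed, a higher number that more compound is needed for the effect; this is a limit of the assay, not a number, and (the limit of > 10000 nM in this assay, at which 2 of the 3 values shown sit). Compound 1 `c1cc(-c2ccn[nH]2)c2c(c1)C(c1ncc[nH]1)CC2` gives 336 nM. Compound 2 `Cn1nccc1-c1cccc2c1CCC2c1ncc[nH]1` likewise returns only the limit > 10000 nM. Two measured steps start from compound 1: an at least 29-fold higher number from compound 1 to compound 2 (1.47 log units; beyond the scatter), and an at least 29-fold higher number from compound 1 to compound 3 (1.47 log units; beyond the scatter). Between the two limits, a step that the two limits leave unreadable from compound 2 to compound 3. The change to compound 4 `Cc1oncc1-c1cccc2c1CCC2c1ncc[nH]1` is 5-methyl-1,2-oxazol-4-yl in place of pyridin-3-yl on an aromatic carbon. Like compound 2 and compound 3, compound 4 lacks the hydrogen on an aromatic nitrogen that compound 1 carries, so the closest guides are two compounds sitting at the limit. Compound 4 is therefore expected to remain at or near the limit, with an expected step of a number no higher from compound 3 to compound 4 (the limit leaves the size open) that the limit makes unreadable. The estimate for compound 4 is 10000 nM, from 3000 nM to 30000 nM.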

Compound 4, half-maximal effective concentration: > 10000 nM
Compound 4 ended at the assay's limit; the forecaster's own chance of this, stated with the estimate: 65%; the middle value sits exactly at the limit.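

In this assay, within the data shown here, the value of compound 4, > 10000 nM, is a limit of the assay, not a number. 5-Methyl-1,2-oxazol-4-yl in place of 1H-pyrazol-5-yl gives an at least 29-fold higher number from compound 1 to compound 4 (1.47 log units; beyond the scatter), so among the four compounds, a number is still seen only with the hydrogen on an aromatic nitrogen of compound 1, now against a five-membered ring with oxygen as well as a pyridine. The steps among compound 2, compound 3 and compound 4 cannot be read: the limit of > 10000 nM in this assay, at which 3 of the 4 values shown sit.

On these data alone, it remains open whether 1H-imidazol-4-yl or an aminopyridine at this position would give a number, and how far compound 2, compound 3 and compound 4 lie apart.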